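The source may report more compounds than this note shows. Statements on the series, on what has been measured and on what is new or still open speak of the compounds shown alone.

Measured compounds:
- compound 1, `N#Cc1ccc(-c2cs/c(=N/NC(=O)CSc3ncccn3)n2-c2ccccc2)cc1`: in a functional assay on C6 cells (Rattus norvegicus) for cytotoxicity, read by MTT assay, with a stated time of 24 h (on this read-out higher numbers stand for weaker inhibition and lower numbers for stronger inhibition), compound 1 gives "not determined" (no result reported).
- compound 2, `Cn1cnnc1SCC(=O)N/N=c1/scc(-c2ccc(C#N)cc2)n1-c1ccccc1`: in this assay compound 2 reaches only a limit, > 200 ug/mL.
- compound 3, `Cc1nnc(SCC(=O)N/N=c2/scc(-c3ccc(C#N)cc3)n2-c2ccccc2)s1`: in this assay compound 3 gives "not determined" (no result reported).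

Compound 1 therefore stands without a number of its own in this assay; of the three compounds sharing its core, only compound 2 has an entry, and that entry is a limit of the assay rather than a measured figure, as noted under (the limit of > 200 ug/mL in this assay, at which 1 of the 3 values shown sits). Compound 3 likewise has no result.

The unmeasured compound 4, `Cc1ccc(-c2cs/c(=N/NC(=O)CSc3ncccn3)n2-c2ccccc2)cc1`, differs from compound 1 in one place: methyl in place of cyano on an aromatic carbon. For the measured compounds named here, no step between measured compounds is available to set a size for this change, so no shift beyond the usual scatter can be claimed in either direction in this assay.

With only the limit of compound 2 as a guide, compound 4 is expected to give about 200 ug/mL in this assay, within 80 ug/mL to 400 ug/mL, and quite possibly again only a limit.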

Compound 4, half-maximal inhibitory concentration: 85 ug/mL
Estimate against measurement, compound 4: 2.4-fold (0.37 log units) above; measured number inside the range.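

In this assay compound 4 gives 85 ug/mL, but compound 1 has no single number there, so no step can be read between compound 1 and compound 4. The compounds shown leave open how far, and in which direction, 4-cyanophenyl and 4-methylphenyl differ in this assay.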